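The source may hold more compounds than are shown below. What is called first, only, known or untested is meant among the compounds shown, and "the series" means these compounds.

Compound 1 `Fc1cc(Cl)ccc1N1CCN(Cc2ccn3c(CC4CC4)nnc3c2C(F)(F)F)CC1`: in a functional assay on HEK293 cells for agonist activity at metabotropic glutamate receptor 5 (Homo sapiens), read by a luciferase reporter and cAMP accumulation (a lower number here means that less compound is needed, a higher number that more compound is needed for the effect), compound 1 gives > 10000 nM, which is a limit of the assay and not a number.
Compound 2 `Fc1ccc(N2CCN(Cc3ccn4c(CC5CC5)nnc4c3C(F)(F)F)CC2)c(Cl)c1`: in this assay compound 2 gives > 10000 nM, likewise a limit of the assay rather than a number.

Compound 2 therefore stands at the limit of this assay, with no number attached to it. Among the measured compounds shown here, the only measured step here, a step that the two limits leave unreadable from compound 1 to compound 2, cannot be read, since both of its ends are limits; this is captured in the limit of > 10000 nM in this assay, at which 2 of the 2 values shown sit.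

Compound 3 `Fc1ccccc1N1CCN(Cc2ccn3c(CC4CC4)nnc3c2C(F)(F)F)CC1` is the next compound, not yet measured in this assay. It differs from compound 2 in one place: 2-fluorophenyl in place of 2-chloro-4-fluorophenyl on an amine nitrogen in a ring. No measured step bears on this change, because the single step shown, a step that the two limits leave unreadable from compound 1 to compound 2, has no readable size. What is shown is only that compound 2 sits at the limit. The expectation for compound 3 therefore rests on that alone, and the step expected is a step that the limit leaves unreadable from compound 2 to compound 3, most likely not beyond the scatter. Compound 3 is estimated at 15000 nM, within a range from 3000 nM to 60000 nM, with a high chance that the assay again reports only a limit.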

Compound 3, half-maximal effective concentration: > 10000 nM
Compound 3: no number, only a limit (the forecaster's own chance of this, stated with the estimate: 80%); the middle value is on the limit's open side.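

In this assay compound 3 gives > 10000 nM, again a limit of the assay and not a number. Among the compounds shown here, the steps linking compound 3 to compound 1 and compound 2 cannot be read, so this result yields no new step: the limit of > 10000 nM in this assay, at which 3 of the 3 values shown sit. The compounds shown leave open how 2-fluorophenyl, 2-chloro-4-fluorophenyl and 4-chloro-2-fluorophenyl compare in this assay.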